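Chloro for fluoro on the anilino ring of compound 2

The source may hold more compounds than are shown below. What is called first, only, known or untested is meant among the compounds shown, and "the series" means these compounds.

Compound 1 `Fc1cccc(-c2nc(Nc3ccccc3)c3cc(F)ccc3n2)c1` and compound 2 `Fc1cccc(Nc2nc(-c3cccc(F)c3)nc3ccc(F)cc23)c1` share one core and differ only in a fluorine on the fused ring. In a functional assay on U2OS cells (Homo sapiens) for cytotoxicity, read by MTT assay, with a stated time of 48 h (on this read-out lower numbers stand for stronger inhibition and higher numbers for weaker inhibition), compound 1 gives 47600 nM and compound 2 gives 49600 nM. Among the measured compounds shown here, the one measured step, a 1.0-fold higher number from compound 1 to compound 2 (0.02 log units; within the scatter), leaves the two numbers indistinguishable. Compound 2 thus stands with the higher of the two numbers, but only by a margin that the scatter swallows, and no order can be read between them.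

Compound 3 `Fc1cccc(-c2nc(Nc3cccc(Cl)c3)c3cc(F)ccc3n2)c1` is not yet measured. Its difference from compound 2 is chloro in place of fluoro on an aromatic carbon. For the measured compounds named here, no measured step touches this halogen exchange: the only step available concerns a fluorine entering the fused ring, not a chlorine replacing a fluorine on the anilino ring. What the data do show is that a small change at a halogen position left this assay unmoved, so the expectation for compound 3 is a step of a 1.0-fold higher number from compound 2 to compound 3 (0.00 log units; within the scatter), that is, nothing beyond the scatter. In this assay compound 3 is therefore estimated at 50000 nM, with a range from 20000 nM to 125000 nM.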

Compound 3, half-maximal inhibitory concentration: > 50000 nM
Compound 3: a limit, no number (the forecaster's own chance of this, stated with the estimate: 15%); the middle value sits exactly at the limit.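

In this assay compound 3 gives > 50000 nM, which is a limit of the assay and not a number. Among the compounds shown here, this is the first look at the exchange of (3-fluorophenyl)amino for (3-chlorophenyl)amino, on an aromatic carbon meta to a large group, and for chloro in place of fluoro here it shows a number no lower from compound 2 to compound 3 (the limit leaves the size open), while the comparison with the unsubstituted anilino compound gives an at least 1.0-fold higher number from compound 1 to compound 3 (0.02 log units; that floor lies within the scatter), a floor that does not separate the two compounds. The size of the step between the fluoro and chloro compounds, and so any real effect of the exchange, cannot be read, because one end of that step is a limit: the limit of > 50000 nM in this assay, at which 1 of the 3 values shown sits.

The compounds shown leave open whether any other group at this position, such as an amine, a methoxy group or a carboxylic acid in place of the chlorine, would bring the number clearly away from that of compound 1. On these data alone, how far compound 3 truly lies from compound 2 also stays open, and only a value within the range of the assay could settle it.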